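Methoxy pattern on the aryl urea of the shared core

The source may report more compounds than this note shows. Statements on the series, on what has been measured and on what is new or still open speak of the compounds shown alone.

Compound 1 `COc1ccc(OC)c(NC(=O)Nc2nn(-c3ccccc3)c(=O)c3ccccc23)c1` carries two methoxy groups on the aryl urea and in an assay on CHO cells for displacement of a labelled ligand from adenosine receptor A1 (Homo sapiens), tested at 10 uM (on this read-out higher numbers stand for more inhibition at the one concentration tested (going by the name of the read-out) and lower numbers for less inhibition), compound 1 gives 0%. Compound 2 `COc1ccccc1NC(=O)Nc1nn(-c2ccccc2)c(=O)c2ccccc12` keeps only one of them; in this assay compound 2 gives 0%, and the step of no change at the digits printed from compound 1 to compound 2 (within the scatter) was hydrogen in place of methoxy on an aromatic carbon. Compound 2 therefore stands level with compound 1, both without measurable inhibition at the one concentration tested. Compound 3 `COc1ccc(NC(=O)Nc2nn(-c3ccccc3)c(=O)c3ccccc23)c(OC)c1` differs from compound 2 by methoxy in place of hydrogen on an aromatic carbon, turning 2-methoxyphenyl into 2,4-dimethoxyphenyl. Among the measured compounds shown here, the only measured step that bears on it, the removal of a methoxy in no change at the digits printed from compound 1 to compound 2 (within the scatter), produced no change beyond the scatter, and both measured compounds sit at the floor of the read-out. A second methoxy is thus expected to leave this assay unchanged, a step of a number 2 percentage points higher from compound 2 to compound 3 (within the scatter). Compound 3 is expected to give 2%, within 0% to 12%.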

Compound 3, a percentage reported as inhibition, at one concentration (the size of the read-out at that concentration, not a potency): 29%
Compound 3: the middle estimate sits 27 percentage points below what was measured; measured number above the stated range.
By their numbers in this assay, from the lowest: compounds 1 and 2 (each within the scatter of the next); then compound 3.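

In this assay, among the compounds shown here, the position para to a large group is the first place on the aryl urea to respond: methoxy there, turning 2-methoxyphenyl into 2,4-dimethoxyphenyl, gives a number 29 percentage points higher from compound 2 to compound 3 (beyond the scatter). Placement of the second methoxy matters as well as its presence, since the change from 2,5-dimethoxyphenyl to 2,4-dimethoxyphenyl reads a number 29 percentage points higher from compound 1 to compound 3 (beyond the scatter), while the step between compound 1 and compound 2 stays within the scatter. No measurement to hand accounts for this difference.

From the compounds shown here alone, whether the response at this position is specific to methoxy remains open, and an amine, a hydroxyl or a longer ethoxy chain there would address it. Also open, going by these compounds, is whether the reading at one concentration for compound 3 would carry over to a true potency.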